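A few compounds are considered here, and "the series" means these few. Any claim that something is new, unique, unknown or untested is made for them only; others in the source may bear on it.

Measured compounds and their values: compound 1 `COc1ccc(/C(=N/O)c2cccc3ccccc23)c(OC)c1OC` with 13100 nM; compound 2 `CCOC(=O)/C=C/CO/N=C(/c1ccc(OC)c(OC)c1OC)c1cccc2ccccc12` with 14000 nM; compound 3 `COc1ccc(/C(=C/c2ccc(F)cc2)c2cccc3ccccc23)c(OC)c1OC` with 18600 nM.

All three were tested in a functional assay on A549 cells (Homo sapiens) for inhibition, read by sulforhodamine B assay, with a stated time of 48 h; on this read-out lower numbers stand for stronger inhibition and higher numbers for weaker inhibition. Compound 2 sits in the middle of the three numbers, and its gaps to compound 1 and to compound 3 are both within the usual scatter, so no order among them can be read from these values.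

The unmeasured compound 4 `COc1ccc(/C(=N/OC(C)=O)c2cccc3ccccc23)c(OC)c1OC` keeps the shared core of compound 2 and changes only the group on the oxime oxygen: acetyl in place of 3-(ethoxycarbonyl)prop-2-en-1-yl on an oxygen. Going by the values given here, the one measured step that touches this position is the one from compound 1 to compound 2, where the same oxygen went from carrying hydrogen to carrying the longer chain: a 1.1-fold higher number from compound 1 to compound 2 (0.03 log units; within the scatter). Among the compounds with values here, that step hardly moved the number, which suggests that what sits on this oxygen has had little bearing on the result so far, at least across the single pair seen. On that basis the step from compound 2 to compound 4 is expected to stay within the scatter, a 1.0-fold lower number from compound 2 to compound 4 (0.02 log units; within the scatter), with no direction favoured.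

Compound 4 is therefore estimated at 13500 nM, with a plausible range from 6000 nM to 30000 nM in this assay.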

Compound 4, half-maximal inhibitory concentration: 17200 nM
The estimate for compound 4 lay 1.3-fold (0.11 log units) below the measured number, within the range that was stated.
By their numbers in this assay, from the lowest: compounds 1, 2, 4 and 3 (each within the scatter of the next).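

Replacing the 3-(ethoxycarbonyl)prop-2-en-1-yl group with acetyl on the oxygen in this assay gives a 1.2-fold higher number from compound 2 to compound 4 (0.09 log units; within the scatter), and replacing hydrogen with acetyl on the same oxygen gives a 1.3-fold higher number from compound 1 to compound 4 (0.12 log units; within the scatter). Going by these compounds alone, the earlier compounds offered only one comparison at this oxygen, whereas three groups can now be compared: hydrogen, a chain of 8 heavy atoms and an acetyl of 3 heavy atoms, and none of the steps among them goes beyond the scatter, so across these three groups neither the size of the group nor the presence of a carbonyl directly on the oxygen is linked to a clear shift in the number. No measurement at hand explains why these values stay so close.

As far as these compounds go, it remains open whether an amine, a carboxylic acid or a benzyl group on this oxygen would shift the number beyond the scatter. It is also unknown whether the same insensitivity would hold in a different cell line or with other changes to the shared core.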